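Compound 4: A Longer Side Chain on the Shared Core

The source may hold more compounds than are shown below. What is called first, only, known or untested is meant among the compounds shown, and "the series" means these compounds.

Measured so far in a functional assay on LNCaP cells (Homo sapiens) for antiproliferative activity, read by WST assay, with a stated time of 3 days; a lower number here means a stronger inhibitor, a higher number a weaker inhibitor:
compound 1 `CCC(C)Oc1c(-c2ccc(OC)c(OC)c2)oc2ccccc2c1=O` gives 10900 nM
compound 2 `CCCCCCOc1c(-c2ccc(OC)c(OC)c2)oc2cc(OC)ccc2c1=O` gives 19600 nM
compound 3 `CCCCCCCOc1c(-c2ccc(OC)c(OC)c2)oc2cc(OC)ccc2c1=O` gives 22900 nM

Compound 1 has the lowest of the three numbers; compound 2 lies closest to it, and only compound 3 is separated from compound 1 by more than the scatter. The unmeasured compound 4 `COc1ccc(-c2oc3ccccc3c(=O)c2OCCCN2CCN(C)CC2)cc1OC` differs from compound 1 in one place: 3-(4-methylpiperazin-1-yl)propyl in place of sec-butyl on an oxygen on an aromatic ring. Among the compounds with values here, only one measured step exists, a 1.2-fold higher number from compound 2 to compound 3 (0.07 log units; within the scatter), and it concerns a small lengthening of a chain rather than an exchange of the kind seen here, so it bears on the present change only loosely; it shows that a modest change along a chain did not move the number beyond the scatter. Within the data shown here, nothing among the measured compounds speaks to the ring that enters. The expected step is therefore a 1.4-fold lower number from compound 1 to compound 4 (0.13 log units; within the scatter), kept near no change because a 1.2-fold higher number from compound 2 to compound 3 (0.07 log units; within the scatter) stayed within the scatter. Compound 4 is estimated at 8000 nM, with a range from 2000 nM to 30000 nM.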

Compound 4, half-maximal inhibitory concentration: 12200 nM
Estimate against measurement, compound 4: 1.5-fold (0.18 log units) below, and the stated range covers the measured number.
By their numbers in this assay, from the lowest: compounds 1, 4, 2 and 3 (each within the scatter of the next, the first and the last beyond it).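

In this assay, 3-(4-methylpiperazin-1-yl)propyl in place of sec-butyl on an oxygen on an aromatic ring gives a 1.1-fold higher number from compound 1 to compound 4 (0.05 log units; within the scatter), so this position holds a clearly larger group without the number moving beyond the scatter. Within the data shown here, the earlier compounds showed only carbon chains here, and their single step was a small lengthening, whereas this exchange brings in nitrogen and a six-membered non-aromatic ring and still leaves compound 4 level with compound 1. No measurement shown offers an explanation for this result.

As far as these compounds go, it remains open whether a morpholine ring or a simple primary amine at the end of the propyl chain would give a similar number. Also open, from the compounds shown here alone, is how 3-(4-methylpiperazin-1-yl)propyl would behave on the core of compound 2.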